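The source may report more compounds than this note shows. Statements on the series, on what has been measured and on what is new or still open speak of the compounds shown alone.

Measured compounds:
Compound 1, `Cc1nc(N2CCC(C(=O)NC(C)C)CC2)nc2ccc(NC(=O)COc3ccc(Cl)cc3)cc12`, gives 15 nM in an assay on CHO-K1 cells for displacement of a labelled ligand from melanin-concentrating hormone receptor 1 (Homo sapiens), with a stated time of 2 h; on this read-out lower numbers stand for stronger inhibition and higher numbers for weaker inhibition.
Compound 2, `Cc1nc(N2CCC(C)(O)CC2)nc2ccc(NC(=O)COc3ccc(Cl)cc3)cc12`, gives 237 nM in this assay.
Compound 3, `Cc1nc(N2CCN(C)CC2)nc2ccc(NC(=O)COc3ccc(Cl)cc3)cc12`, gives 220 nM in this assay.

Compound 3 stands second highest of the three numbers. Its nearest neighbour is compound 2: the step of a 1.1-fold lower number from compound 2 to compound 3 (0.03 log units; within the scatter) lies within the scatter, so the two are not separated. Compound 1 sits far below both, with a number well beyond the scatter from compound 3.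

Compound 4, `Cc1nc(N2CCC(O)CC2)nc2ccc(NC(=O)COc3ccc(Cl)cc3)cc12`, differs from compound 3 in one place: 4-hydroxypiperidin-1-yl in place of 4-methylpiperazin-1-yl on an aromatic carbon. Going by the values given here, the only measured step that bears on this exchange is a 1.1-fold lower number from compound 2 to compound 3 (0.03 log units; within the scatter), which swapped a piperidine bearing both a hydroxyl and a methyl for the methylpiperazine without a shift beyond the scatter. Among the compounds with values here, compound 4 carries a hydroxypiperidine that lacks only that methyl, so the account has no measured step that would move the number far. Compound 4 is therefore expected to show a step of a 1.0-fold lower number from compound 3 to compound 4 (0.02 log units; within the scatter) in this assay, that is, no change beyond the scatter. The estimate for compound 4 is 210 nM, with a range from 70 nM to 630 nM.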

Compound 4, half-maximal inhibitory concentration: 150 nM
For compound 4 the middle estimate is 1.4-fold (0.15 log units) above the measured one; measured number inside the range.
By their numbers in this assay, from the lowest: compound 1; then compounds 4, 3 and 2 (each within the scatter of the next).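

In this assay, 4-hydroxypiperidin-1-yl in place of 4-methylpiperazin-1-yl on the aromatic carbon between two ring nitrogen atoms gives a 1.5-fold lower number from compound 3 to compound 4 (0.17 log units; within the scatter), and hydrogen in place of methyl on the saturated ring carbon gives a 1.6-fold lower number from compound 2 to compound 4 (0.20 log units; within the scatter), so neither exchange separates these compounds. Isopropylcarbamoyl remains the one group here that stands apart, since hydroxy in its place on the saturated ring carbon gives a 10-fold higher number from compound 1 to compound 4 (1.00 log units; beyond the scatter). No measurement shown offers a reason for these numbers. Still open, on these data alone, is whether a primary amine or a carboxylic acid on that saturated ring carbon would stand with compound 1 or with compound 4. Also open, as far as these compounds go, is whether a longer amide chain in place of isopropylcarbamoyl would keep the number of compound 1.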